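Swapping the amine side chain in a sulfamate series

A few compounds are considered here, and "the series" means these few. Any claim that something is new, unique, unknown or untested is made for them only; others in the source may bear on it.

Three compounds sharing one sulfamate core were tested in an assay on HEK293 cells for inhibition of Steryl-sulfatase (Homo sapiens), tested at 1 uM; a higher number here means a stronger effect of the compound at the concentration tested, a lower number a weaker effect. Compound 1 `NS(=O)(=O)Oc1ccc2c(c1)CN(C(=O)c1cccc(N3CCC(Cc4ccccc4)CC3)c1)CC2` gives 41.9%. Compound 2 `CN(CCCN1CCCCC1)c1ccc(C(=O)N2CCc3ccc(OS(N)(=O)=O)cc3C2)cc1` gives 40.7%. Compound 3 `CCN(Cc1ccccn1)c1cccc(C(=O)N2CCc3ccc(OS(N)(=O)=O)cc3C2)c1` gives 19.9%. On these numbers compound 2 sits alongside compound 1, their values lying within the usual scatter, and clearly above compound 3, a gap that is beyond the scatter.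

Compound 4 `CN(C)CCN(CCN(C)C)c1ccc(C(=O)N2CCc3ccc(OS(N)(=O)=O)cc3C2)cc1` has not yet been measured. It differs from compound 2 in one place: bis(2-(dimethylamino)ethyl)amino in place of methyl(3-(piperidin-1-yl)propyl)amino on an aromatic carbon. One basic, ring-free side chain replaces another basic side chain, while the rest of the molecule is unchanged.

Among the measured compounds shown here, no measured pair here shows a step of exactly this kind, so the expectation rests on compound 2 alone. Because compound 2 gives 40.7% and the change keeps the overall shape of the side chain, only a modest step is expected, a number 5.7 percentage points lower from compound 2 to compound 4 (within the scatter), likely downward but possibly within the scatter. Compound 4 is therefore estimated at 35% in this assay, with a range from 15% to 55%.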

Compound 4, a percentage reported as inhibition, at one concentration (the size of the read-out at that concentration, not a potency): 15.9%
For compound 4 the middle estimate is 19.1 percentage points above the measured one; the range from low to high includes it.
By their numbers in this assay, from the lowest: compounds 4 and 3 (each within the scatter of the next); then compounds 2 and 1 (each within the scatter of the next).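

Replacing methyl(3-(piperidin-1-yl)propyl)amino with bis(2-(dimethylamino)ethyl)amino gives a number 24.8 percentage points lower from compound 2 to compound 4 (beyond the scatter) in this assay, so the read-out at this position on the aromatic carbon depends on the make-up of the side chain, not only on its size. The two groups have the same heavy-atom count, yet the entering group has no ring and carries more nitrogen than the one it replaces. No separate measurement accounts for the step.

The ring and the nitrogen count change together in this single pair, so their contributions remain unseparated. A side chain such as methyl(3-(dimethylamino)propyl)amino, with no ring and no added nitrogen compared with the group in compound 2, would help tell the two apart.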